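A few compounds are considered here, and "the series" means these few. Any claim that something is new, unique, unknown or untested is made for them only; others in the source may bear on it.

Measured compounds:
- Compound 1 `CCN(CC)S(=O)(=O)c1ccc(S(=O)(=O)N2CCC[C@@H](C(=O)N3CCN(c4nc(C(F)(F)F)no4)CC3)C2)cc1`. In a functional assay on MIA PaCa-2 cells (Homo sapiens) for inhibition, read by MTT assay, with a stated time of 3 days (on this read-out higher numbers stand for weaker inhibition and lower numbers for stronger inhibition), compound 1 gives > 10000 nM, which is a limit of the assay and not a number.
- Compound 2 `CCOC(=O)[C@@H]1C[C@@H](O)CN(S(=O)(=O)c2ccc(S(=O)(=O)N(CC)CC)cc2)C1`. In this assay compound 2 gives > 10000 nM, again a limit rather than a number.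
- Compound 3 `CC(C)c1noc(N2CCN(C(=O)[C@@H]3CCCN(S(=O)(=O)c4ccc(S(=O)(=O)C5CCC5)cc4)C3)CC2)n1`. In this assay compound 3 gives > 10000 nM, also a limit and not a number.

All three measured compounds thus sit at the same point: the limit of > 10000 nM in this assay, at which 3 of the 3 values shown sit. Compound 3 therefore stands nowhere in particular among the numbers shown, since every one of them is a limit and none separates from the others. Within the data shown here, no step between two measured compounds that differ in a single place is available, so nothing here shows how a change at one spot moves the read-out.

Compound 4 `CC(C)c1noc(N2CCN(C(=O)[C@@H]3CCCN(S(=O)(=O)c4ccc(S(=O)(=O)C(C)C)cc4)C3)CC2)n1` has not yet been measured. It differs from compound 3 in one place: isopropyl in place of cyclobutyl on a sulfonyl sulfur. Among the measured compounds shown here, with only limits on hand, and no measured step to draw on, the expected step from compound 3 to compound 4, a step that the limit leaves unreadable from compound 3 to compound 4, is essentially none beyond the scatter, and the most likely outcome is that compound 4 also returns a limit. The estimate for compound 4 in this assay is 20000 nM, expected to fall between 5000 nM and 80000 nM.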

Compound 4, half-maximal inhibitory concentration: > 10000 nM
Compound 4: no number, only a limit; the forecaster's own chance of this, stated with the estimate: 85%; the middle value lies beyond the limit too.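

In this assay compound 4 gives > 10000 nM, a limit and not a number. Compound 3 also sits at a limit, so no step can be read between compound 3 and compound 4. The compounds shown leave open how a change at any one place moves the read-out, as they all stop at one point: the limit of > 10000 nM in this assay, at which 4 of the 4 values shown sit.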